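Chain extension on the amide of compound 3

A few compounds are considered here, and "the series" means these few. Any claim that something is new, unique, unknown or untested is made for them only; others in the source may bear on it.

Compound 3 `CCCC(=O)Nc1c(OS(=O)(=O)c2ccc(C)cc2)c2ccccc2oc1=O` gives 75000 nM in a functional assay on MCF7 cells (Homo sapiens) for antiproliferative activity, read by MTT assay, with a stated time of 72 h (on this read-out lower numbers stand for stronger inhibition and higher numbers for weaker inhibition), the highest of the three numbers, though compound 1 `COc1cc(C(=O)Nc2c(OS(=O)(=O)c3ccc(C)cc3)c3ccccc3oc2=O)cc(OC)c1OC` at 40000 nM lies within the scatter of it; compound 2 `Cc1ccc(S(=O)(=O)Oc2c(NC(=O)c3ccc4c(c3)C=CC(C)(C)O4)c(=O)oc3ccccc23)cc1` gives 35000 nM. Compound 4 `CCCCCCCCCCCCC(=O)Nc1c(OS(=O)(=O)c2ccc(C)cc2)c2ccccc2oc1=O` differs from compound 3 in nonyl in place of hydrogen on a saturated chain carbon, three bonds along the chain from a carbonyl carbon. The measured steps all concern the group on the carbonyl carbon: a 1.9-fold higher number from compound 1 to compound 3 (0.27 log units; within the scatter) and a 2.1-fold higher number from compound 2 to compound 3 (0.33 log units; beyond the scatter), the latter modest, alongside a 1.1-fold lower number from compound 1 to compound 2 (0.06 log units; within the scatter). None of them lengthens a chain, so they bear on the present step only by showing that exchanges at this position shift the number little. No step beyond the scatter is therefore expected in this assay, and for compound 4 the estimate is 70000 nM (range 25000 nM to 200000 nM), an expected 1.1-fold lower number from compound 3 to compound 4 (0.03 log units; within the scatter).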

Compound 4, half-maximal inhibitory concentration: 50000 nM
Compound 4: the middle estimate sits 1.4-fold (0.15 log units) above what was measured; measured number inside the range.
By their numbers in this assay, from the lowest: compounds 2, 1, 4 and 3 (each within the scatter of the next, the first and the last beyond it).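

Nonyl in place of hydrogen on a saturated chain carbon, three bonds along the chain from a carbonyl carbon, is the first chain extension at this position, and in this assay it gives a 1.5-fold lower number from compound 3 to compound 4 (0.18 log units; within the scatter). Dodecyl on the carbonyl carbon also shows no step beyond the scatter from either aromatic group, with a 1.3-fold higher number from compound 1 to compound 4 (0.10 log units; within the scatter) and a 1.4-fold higher number from compound 2 to compound 4 (0.15 log units; within the scatter). No evidence at hand explains these numbers.

Still open, from the compounds shown here alone, is whether a carboxylic acid or an amine on the chain, or a chain longer than dodecyl, would give a step beyond the scatter.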